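Lengthening the hydroxamate linker on a saturated bicyclic core

The source may hold more compounds than are shown below. What is called first, only, known or untested is meant among the compounds shown, and "the series" means these compounds.

Three compounds share a methyl-bridged anilino-ether motif ending in a hydroxamic acid. Compound 1 `Cc1nc(N(C)c2ccc(OCCCCC(=O)NO)cc2)c2ccccc2n1` gives 1700 nM in an assay on isolated protein for inhibition of histone deacetylase 8 (Homo sapiens), read by fluorescence, with a stated time of 1 h; on this read-out higher numbers stand for weaker inhibition and lower numbers for stronger inhibition. Compound 2 `CN(c1ccc(OCCCC(=O)NO)cc1)c1ncnc2ccccc12` gives 2460 nM in this assay. Compound 3 `Cc1nc2c(c(N(C)c3ccc(OCCCC(=O)NO)cc3)n1)CCC2` gives 6190 nM in this assay, the highest number of the three, with both gaps to compound 2 and to compound 1 lying beyond the scatter. Compound 1 and compound 2 differ in their cores as well as in their chains, so their values are noted side by side without a step drawn between them.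

Compound 4 `Cc1nc2c(c(N(C)c3ccc(OCCCCCC(=O)NO)cc3)n1)CCC2` is not yet measured. It differs from compound 3 in one place: 2-(hydroxycarbamoyl)ethyl in place of hydroxycarbamoyl on a saturated chain carbon, three bonds along the chain from an oxygen on an aromatic ring. Among the compounds with values here, no measured pair isolates this change. The expectation for compound 4 is therefore cautious: a step of modest size from compound 3 to compound 4 of a 1.5-fold lower number from compound 3 to compound 4 (0.19 log units; within the scatter), with no direction assured beyond the scatter. Compound 4 is estimated at 4000 nM in this assay, within a range from 1500 nM to 11000 nM.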

Compound 4, half-maximal inhibitory concentration: 1000 nM
The estimate for compound 4 lay 4.0-fold (0.60 log units) above the measured number; measured number outside the range, below it.
By their numbers in this assay, from the lowest: compounds 4, 1 and 2 (each within the scatter of the next, the first and the last beyond it); then compound 3.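

In this assay the move from hydroxycarbamoyl to 2-(hydroxycarbamoyl)ethyl, on a saturated chain carbon, three bonds along the chain from an oxygen on an aromatic ring, brings a 6.2-fold lower number from compound 3 to compound 4 (0.79 log units; beyond the scatter) on an otherwise unchanged structure. Within the data shown here, this is the first pair here that isolates chain length, and it shows that inhibition at this position responds to that length, with the longer chain giving the lower number by a margin beyond the scatter. No measurement bears on why the added length has this effect.

As far as these compounds go, whether a still longer chain would go further the same way or reverse the step remains open, as does whether a carboxylic acid could stand in for the hydroxycarbamoyl end. From the compounds shown here alone, it is also open whether the same lengthening would give a similar step on the core of compound 1 or compound 2.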